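Swapping Chloro for Bromo: What to Expect for Compound 4

This account rests on a few compounds, and the source may have more. Where it says the series, first, only, none or still open, it means among the compounds named here.

Compound 1, `COc1ccc(/C=N/NC(=O)COc2cccc3ccccc23)cc1OC`, gives 52.6 ug/mL in an ADME assay on HEL cells (Homo sapiens) for cytotoxicity; on this read-out lower numbers stand for higher toxicity in this test and higher numbers for lower toxicity in this test.
Compound 2, `O=C(COc1cccc2ccccc12)N/N=C/c1ccc(Cl)cc1`, gives 100 ug/mL in this assay.
Compound 3, `C/C(=N\NC(=O)COc1cccc2ccccc12)c1ccc(Br)cc1`, gives 15.3 ug/mL in this assay.

Compound 2 holds the highest of the three numbers, which on this read-out means the least toxicity seen so far. Its closest neighbour is compound 1, and that gap lies within the usual scatter, so the two cannot be ranked against each other. Compound 3 lies beyond the scatter below compound 2 and is therefore clearly more toxic in this test.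

Compound 4, `O=C(COc1cccc2ccccc12)N/N=C/c1ccc(Br)cc1`, has not yet been measured in this assay. It differs from compound 2 in a single place: bromo in place of chloro on an aromatic carbon. The group that leaves and the group that enters each count one heavy atom, and neither adds a ring, a hydrogen-bond donor or acceptor, or a charge. For the measured compounds named here, no measured pair shows this exact exchange on its own. Compound 3 also carries bromo, but it differs from compound 4 in a second place as well, so its value only shows that a bromo-bearing relative can sit well below compound 2. The step is expected to be modest and downward, a 1.7-fold lower number from compound 2 to compound 4 (0.22 log units; within the scatter). Compound 4 is expected to give 60 ug/mL, within a range from 25 ug/mL to 100 ug/mL.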

Compound 4, half-maximal cytotoxic concentration: 100 ug/mL
For compound 4 the middle estimate is 1.7-fold (0.22 log units) below the measured one, and the stated range covers the measured number.
By their numbers in this assay, from the lowest: compound 3; then compounds 1, 2 and 4 (each within the scatter of the next).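

The step from chloro to bromo at this place, on an aromatic carbon para to a large group, can now be read on its own in this assay, and it shows no change at the digits printed from compound 2 to compound 4 (within the scatter). Bromo therefore does not by itself set this series apart here: compound 3 gives 15.3 ug/mL, whereas compound 4, which also carries bromo on its 4-bromophenyl group, gives 100 ug/mL, so the low number of compound 3 cannot be read as a simple bromo effect. Nothing in the available data explains why the two halogens read alike here.

The compounds shown cover only these two halogens at this place, so it remains open whether fluoro, an amine, a nitrile or a carboxylic acid on the same carbon would leave the number as it stands or move it. For the compounds shown here, it is also open whether chloro and bromo would read alike in a relative of compound 3, which is the only compound here that carries the extra methyl group on the carbon of the carbon-nitrogen double bond.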